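Cyclising the selenosemicarbazone of compound 1 to the ring

This account rests on a few compounds, and the source may have more. Where it says the series, first, only, none or still open, it means among the compounds named here.

Within the data shown here, compound 1 `NC(=[Se])N/N=C/c1csc(-c2ccccc2)n1` holds the only numerical value: in a functional assay on DU-145 cells (Homo sapiens) for cytotoxicity, read by XTT assay, with a stated time of 72 h (on this read-out higher numbers stand for weaker inhibition and lower numbers for stronger inhibition), compound 1 gives 6140 nM. Compound 2 `ClCc1c[se]c(N/N=C/c2ccc(Cl)cc2)n1` reaches only a limit in this assay, > 75000 nM. Compound 3 `COc1ccc(/C=N/Nc2nc(C)c[se]2)cc1` likewise stops at a limit in this assay, > 84900 nM. Compound 4 `ClCc1c[se]c(N/N=C/c2csc(-c3ccccc3)n2)n1` differs from compound 1 by a group of 7 heavy atoms (4 carbon, 1 nitrogen, 1 chlorine, 1 selenium; one five-membered aromatic ring with 2 hetero atoms) in place of a group of 3 heavy atoms (1 carbon, 1 nitrogen, 1 selenium; no ring), on an amine nitrogen. Among the measured compounds shown here, no measured pair isolates this change. Given the limit of > 75000 nM in this assay, at which 1 of the 3 values shown sits, and (the limit of > 84900 nM in this assay, at which 1 of the 3 values shown sits), both from compounds bearing this ring, the expected step is a 4.9-fold higher number from compound 1 to compound 4 (0.69 log units; beyond the scatter), towards weaker inhibition and beyond the scatter. Compound 4 is estimated at 30000 nM in this assay, between 8000 nM and 100000 nM.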

Compound 4, half-maximal inhibitory concentration: 16400 nM
For compound 4 the middle estimate is 1.8-fold (0.26 log units) above the measured one; the measured number falls inside the stated range.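

In this assay, the five-membered aromatic ring with 2 hetero atoms on the amine nitrogen, in place of the open selenium-bearing group, gives a 2.7-fold higher number from compound 1 to compound 4 (0.43 log units; beyond the scatter), a modest move towards weaker inhibition. The open group is therefore not required for a measured number at this position, since compound 4 still gives a value and not a limit. This rests on a single pair.

As far as these compounds go, whether the ring's activity depends on its selenium or its chlorine stays open. A sulfur atom in place of the selenium, or an amine in place of the chlorine, would test this.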